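Thienopyrimidine series: heteroaryl swap at compound 4

The source may hold more compounds than are shown below. What is called first, only, known or untested is meant among the compounds shown, and "the series" means these compounds.

Measured so far in a functional assay on CHO-K1 cells for antagonist activity at adenosine receptor A1 (Homo sapiens), read by a beta-galactosidase reporter and cAMP accumulation, with stated times of 15 min and 6 h; on this read-out higher numbers stand for weaker inhibition and lower numbers for stronger inhibition:
compound 1 `CC(C)c1ccc(-c2nc(N)c3cc(Cc4ccccc4)sc3n2)o1`: 283 nM
compound 2 `Nc1nc(-c2ccc(C(F)F)o2)nc2sc(Cc3ccccc3)cc12`: 3000 nM
compound 3 `COc1ccccc1Cc1cc2c(N)nc(-c3ccc(C(F)F)o3)nc2s1`: 516 nM

Compound 3 sits second highest of the three numbers. Its nearest neighbour is compound 1, a gap that stays within the scatter, so no order between these two can be claimed; compound 2 lies clearly further off, and the step of a 5.8-fold lower number from compound 2 to compound 3 (0.76 log units; beyond the scatter) is beyond the scatter.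

Compound 4 `COc1ccccc1Cc1cc2c(N)nc(-c3nc(C)cs3)nc2s1` differs from compound 3 in one place: 4-methyl-1,3-thiazol-2-yl in place of 5-(difluoromethyl)furan-2-yl on an aromatic carbon. Neither measured step changes this group. The step of an 11-fold higher number from compound 1 to compound 2 (1.03 log units; beyond the scatter) alters only the substituent on the same five-membered ring and shows that this part of the molecule can move the number a long way; the step of a 5.8-fold lower number from compound 2 to compound 3 (0.76 log units; beyond the scatter) concerns the benzyl group and says nothing about the heteroaryl. Among the compounds with values here, no measured step therefore bears directly on the change to compound 4, and the expected step of a 1.5-fold lower number from compound 3 to compound 4 (0.17 log units; within the scatter) is set small, with a wide range in both directions. Compound 4 is accordingly estimated at 350 nM, within 70 nM to 1800 nM.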

Compound 4, inhibition constant: 186 nM
For compound 4 the middle estimate is 1.9-fold (0.27 log units) above the measured one, within the range that was stated.
By their numbers in this assay, from the lowest: compounds 4, 1 and 3 (each within the scatter of the next, the first and the last beyond it); then compound 2.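

In this assay, the position between two ring nitrogen atoms tolerates replacement of the whole five-membered aromatic ring, not only of its substituent: 4-methyl-1,3-thiazol-2-yl in place of 5-(difluoromethyl)furan-2-yl gives a 2.8-fold lower number from compound 3 to compound 4 (0.44 log units; beyond the scatter) on the 2-methoxybenzyl background. A furan-2-yl group is therefore not required at this position for a number in this range. Ring and substituent change together in this step, and nothing available explains its direction or size.

On these data alone, whether the lower number belongs to the ring with 2 hetero atoms or to its methyl group stays open, as does whether the step holds with the unsubstituted benzyl group of compound 2. As far as these compounds go, the effect of an ethyl group or an aminomethyl group in place of that methyl also remains open.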